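A few compounds are considered here, and "the series" means these few. Any claim that something is new, unique, unknown or untested is made for them only; others in the source may bear on it.

Three compounds that share one core were examined in an ADME assay on Vero cells (Chlorocebus sabaeus) for cytotoxicity, read by resazurin assay, with a stated time of 3 days; on this read-out higher numbers stand for weaker inhibition and lower numbers for stronger inhibition. Compound 1 `CCCCCC(=O)Nc1cc2nc(C3CCCCC3)[nH]c2cc1N1CCCC1` gives > 100 ug/mL, which is a limit of the assay rather than a measured number. Compound 3 `O=C(CCc1ccccc1)Nc1cc2nc(C3CCCCC3)[nH]c2cc1N1CCCC1` gives > 100 ug/mL, again only a limit. Between these two the step that the two limits leave unreadable from compound 1 to compound 3 can be stated as a structural change, but its size cannot be read, since both ends are limits. Compound 2 `CCOCCOC(=O)Nc1cc2nc(C3CCCCC3)[nH]c2cc1N(C)C` gives > 100 ug/mL, once more a limit and not a number. Compound 2 thus stands exactly where the other two stand, at the limit of > 100 ug/mL in this assay, at which 3 of the 3 values shown sit; nothing among the numbers sets it apart from compound 1 or compound 3.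

Compound 4 `CCCOCC(=O)Nc1cc2nc(C3CCCCC3)[nH]c2cc1N(C)C` is the next compound in line. It differs from compound 2 by propoxymethyl in place of 2-ethoxyethoxy on a carbonyl carbon. Among the measured compounds shown here, no measured step bears directly on this exchange; the one step that has been measured, from compound 1 to compound 3, has no readable size, and it concerns a different part of the chain. With every measured compound at the same limit, the account can only expect that compound 4 behaves like its neighbours, that is, a step of a number no higher from compound 2 to compound 4 (the limit leaves the size open) that does not rise beyond the scatter. The estimate for compound 4 is therefore 100 ug/mL, in a range from 50 ug/mL to 200 ug/mL.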

Compound 4, half-maximal inhibitory concentration: < 50 ug/mL
Compound 4: a limit, no number; the forecaster's own chance of this, stated with the estimate: 85%; middle value at least 2.0-fold (0.30 log units) away from the limit.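

In this assay, among the compounds shown here, the exchange of 2-ethoxyethoxy for propoxymethyl on a carbonyl carbon, whose other neighbour is an amide-type nitrogen, comes with an at least 2.0-fold lower number from compound 2 to compound 4 (0.30 log units; that floor lies within the scatter), and this is the first step in the set whose size can be read at all, if only as a floor. The earlier compounds showed only that the chain change from compound 1 to compound 3 could not be read, so this carbonyl carbon is the first place shown where a change takes a compound away from the upper limit. Compound 4 is also the only compound shown at this lower limit, which is a limit of the assay and not a number: the limit of < 50 ug/mL in this assay, at which 1 of the 4 values shown sits.

The compounds shown do not separate the parts of this exchange, with 6 heavy atoms and 2 oxygens leaving and 5 heavy atoms and 1 oxygen entering, and without a number for compound 4 the full size of the step stays open. They also leave open what a longer ether chain, or a chain ending in an amine or a carboxylic acid, would give on this carbonyl carbon in this assay.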